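Benzyloxycarbonyl in place of fluoro on the benzimidazole-type core

The source may hold more compounds than are shown below. What is called first, only, known or untested is meant among the compounds shown, and "the series" means these compounds.

Compound 1: `Fc1ccc2[nH]c(-c3cn(-c4ccccc4)nc3-c3ccccc3)nc2c1`, 2430 nM
Compound 2: `Cc1cc2nc(-c3cn(-c4ccccc4)nc3-c3ccccc3)[nH]c2cc1C`, > 50000 nM

The two measured compounds share a core and differ only in what sits on its six-membered carbon ring. Among the measured compounds shown here, in a functional assay on MCF7 cells (Homo sapiens) for antiproliferative activity, read by MTT assay, with a stated time of 48 h (on this read-out higher numbers stand for weaker inhibition and lower numbers for stronger inhibition), compound 1 gives 2430 nM, and this is the only number recorded; the other entry is not a number. Compound 2 reaches only the limit of the assay, > 50000 nM, and no value beyond that limit is known (the limit of > 50000 nM in this assay, at which 1 of the 2 values shown sits). For the measured compounds named here, no pair of measured compounds differs in exactly one place, so no measured step can be drawn.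

Compound 3, `O=C(OCc1ccccc1)c1ccc2[nH]c(-c3cn(-c4ccccc4)nc3-c3ccccc3)nc2c1`, has not yet been measured. It differs from compound 1 in one place: benzyloxycarbonyl in place of fluoro on an aromatic carbon. Going by the values given here, because the only reference is the value of compound 1 at 2430 nM, and the entering group is far larger than the leaving fluoro, the step from compound 1 to compound 3 is expected to be a modest loss, a 2.5-fold higher number from compound 1 to compound 3 (0.39 log units; beyond the scatter), though a step within the scatter cannot be excluded. Compound 3 is therefore estimated at 6000 nM, in the range 1200 nM to 40000 nM.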

Compound 3, half-maximal inhibitory concentration: 12600 nM
Beside the measured number, compound 3's estimate is 2.1-fold (0.32 log units) below it, and the stated range covers the measured number.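

Compound 3 shows that this aromatic carbon, meta to a fused ring and para to a fused ring, can carry a far larger group than fluoro without activity disappearing: in this assay, compound 3 still gives a measured 12600 nM. Benzyloxycarbonyl in place of fluoro produces a 5.2-fold higher number from compound 1 to compound 3 (0.71 log units; beyond the scatter), so this change has a real but modest cost, and it gives the series its first measured single-place step. No measurement shown bears on why the number rises with this change.

The compounds shown leave open which part of the benzyloxycarbonyl group carries the loss, the six-membered aromatic ring it brings or the ester link that joins that ring to the core, and a carboxylic acid, a methyl ester or a benzyl amide on the same aromatic carbon would help to separate these parts. They also leave open how this carbon responds to a small group other than fluoro, such as chloro, methoxy or an amine.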